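Amide aryl changes on the piperidine sulfonamide series

The source may report more compounds than this note shows. Statements on the series, on what has been measured and on what is new or still open speak of the compounds shown alone.

Compound 2 `O=C(c1ccccn1)N1CCC(NS(=O)(=O)c2cc(S(=O)(=O)c3ccccc3)ccc2C(F)(F)F)CC1` holds the lowest number of the two measured in an assay on U2OS cells for inhibition of secreted frizzled-related protein 1 (Homo sapiens), read by a luciferase reporter, with a stated time of 18 h; a lower number here means that less compound is needed, a higher number that more compound is needed for the effect; compound 2 gives 230 nM. Its nearest neighbour is compound 1 `O=C(c1ccc(C(F)(F)F)cc1)N1CCC(NS(=O)(=O)c2cc(S(=O)(=O)c3ccccc3)ccc2C(F)(F)F)CC1`, which in this assay gives 970 nM, and the step of a 4.2-fold lower number from compound 1 to compound 2 (0.63 log units; beyond the scatter) shows that the group on the carbonyl carbon moves the number by a modest but real amount. Compound 3 `O=C(c1ccc(Cl)nc1)N1CCC(NS(=O)(=O)c2cc(S(=O)(=O)c3ccccc3)ccc2C(F)(F)F)CC1` is the next variation at the same place: 6-chloropyridin-3-yl in place of pyridin-2-yl on a carbonyl carbon. Within the data shown here, the only step that bears on it is the one from compound 1 to compound 2, which changed the same aryl group, so the position is known to matter, but no measured pair shows the effect of moving the ring nitrogen or adding chlorine. A step of moderate size is therefore expected, more likely towards a higher number than a lower one, a 2.0-fold higher number from compound 2 to compound 3 (0.29 log units; within the scatter). Compound 3 is estimated at 450 nM, within 150 nM to 1400 nM.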

Compound 3, half-maximal effective concentration: 140 nM
Beside the measured number, compound 3's estimate is 3.2-fold (0.51 log units) above it; measured number outside the range, below it.
By their numbers in this assay, from the lowest: compounds 3 and 2 (each within the scatter of the next); then compound 1.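

The aryl group on the carbonyl carbon accepts 6-chloropyridin-3-yl in place of pyridin-2-yl with a 1.6-fold lower number from compound 2 to compound 3 (0.22 log units; within the scatter) in this assay, so these two pyridine amides cannot be told apart here. Against 4-(trifluoromethyl)phenyl, the chlorinated pyridine gives a 6.9-fold lower number from compound 1 to compound 3 (0.84 log units; beyond the scatter), which shows that the advantage over compound 1 is not confined to pyridin-2-yl and holds for both pyridine amides shown. No supporting data on these compounds offer an explanation for either step.

The step from pyridin-2-yl to 6-chloropyridin-3-yl moves the point of attachment and adds chlorine together, so the contribution of each remains unresolved. Unsubstituted pyridin-3-yl would separate the two, and it remains open how an amine or a nitrile in place of the chlorine would read.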